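The compounds below may be only part of what the source reports. "The series", "measured", "known", "first", "only" and "open" are said of these compounds alone.

Three closely related acids have been measured in an ADME assay on liver (Mus musculus) for metabolic stability, read by LC-MS, using microsomes and NADPH (a higher number here means that more of the compound is left, a lower number that less of the compound is left), and they differ only in how one stereocentre is drawn. Compound 1 `CCCN(Cc1ccc(OCCN2C(=O)CCC2=O)c(C)c1)C(CC(=O)O)c1ccc(Cl)cc1`, drawn without a configuration there, gives 75%. Compound 2 `CCCN(Cc1ccc(OCCN2C(=O)CCC2=O)c(C)c1)[C@@H](CC(=O)O)c1ccc(Cl)cc1`, drawn S, gives 97%, the highest of the three and close to the top of the scale. Compound 3 `CCCN(Cc1ccc(OCCN2C(=O)CCC2=O)c(C)c1)[C@H](CC(=O)O)c1ccc(Cl)cc1`, drawn R, gives 69%. The step of a number 28 percentage points lower from compound 2 to compound 3 (beyond the scatter) can be put down to the fact that compounds 2 and 3 differ only in the configuration as drawn, and the step of a number 22 percentage points higher from compound 1 to compound 2 (beyond the scatter) goes with the fact that one of compounds 1 and 2 is drawn with a defined configuration and the other without, at the place where they differ. The step of a number 6 percentage points lower from compound 1 to compound 3 (within the scatter) goes with the fact that one of compounds 1 and 3 is drawn with a defined configuration and the other without, at the place where they differ.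

Compound 4 `Cc1cc(CN(CC2CC2)[C@@H](CC(=O)O)c2ccc(Cl)cc2)ccc1OCCN1C(=O)CCC1=O` changes something else: cyclopropyl in place of ethyl on a saturated chain carbon bound to an amine nitrogen. In words, this is cyclopropyl in place of ethyl on a saturated chain carbon bound to an amine nitrogen, which also reads as propyl to cyclopropylmethyl. Among the measured compounds shown here, no measured step touches this chain, so none of them bears on the change directly. They show only that a small alteration can move this assay modestly, as the step of a number 28 percentage points lower from compound 2 to compound 3 (beyond the scatter) does. With compound 2 so near the top, any sizeable move could only be downward, so the expected step is a number 7 percentage points lower from compound 2 to compound 4 (within the scatter), with nothing beyond the scatter expected. For compound 4 the estimated value is 90%, with an expected range from 70% to 100%.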

Compound 4, percent of the compound remaining: 87%
The estimate for compound 4 lay 3 percentage points above the measured number; the measured number falls inside the stated range.
By their numbers in this assay, from the lowest: compounds 3 and 1 (each within the scatter of the next); then compounds 4 and 2 (each within the scatter of the next).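

In this assay, cyclopropyl in place of ethyl on a saturated chain carbon bound to an amine nitrogen gives a number 10 percentage points lower from compound 2 to compound 4 (within the scatter). Among the compounds shown here, the earlier compounds varied only how the stereocentre is drawn, so this is the first sign that the chain on the amine nitrogen can be altered, here by adding a small ring, with no change in this read-out that can be told apart from the usual scatter. None of the available evidence concerns this chain or this ring, so the result has no explanation here.

The compounds shown leave open how a longer chain such as butyl, a larger ring such as cyclobutyl, or a chain carrying an ether oxygen would fare at this place in this assay, and whether cyclopropyl would behave in the same way on the form drawn R, compound 3. With a single change at this position, there is also no way yet to say whether the outcome for compound 4 reflects a general tolerance of this chain to alteration or holds for cyclopropyl alone.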